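The source may hold more compounds than are shown below. What is called first, only, known or untested is meant among the compounds shown, and "the series" means these compounds.

Compound 2 `CN1C[C@@H]2CN(c3ccc(-c4cccc(-c5ccccc5)c4)nc3)C[C@@H]2C1` was tested in an assay on membranes from brain for displacement of a labelled ligand from Neuronal acetylcholine receptor; alpha4/beta2 (Rattus norvegicus) (on this read-out higher numbers stand for weaker inhibition and lower numbers for stronger inhibition), where compound 2 gives 9800 nM. Going by the values given here, that is the highest of the two numbers measured so far. The nearest is compound 1 `Cc1cccc(-c2ccc(N3C[C@H]4CN(C)C[C@H]4C3)cn2)c1`, which differs from compound 2 only in carrying a methyl where compound 2 carries a phenyl; in this assay compound 1 gives 750 nM. The step of a 13-fold higher number from compound 1 to compound 2 (1.12 log units; beyond the scatter) shows that exchanging the methyl for the phenyl weakened binding markedly.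

Compound 3 `COc1cccc(-c2ccc(N3C[C@H]4CN(C)C[C@H]4C3)cn2)c1` is the next compound to be measured: methoxy in place of phenyl on an aromatic carbon. The phenyl that compound 2 carries is thus replaced by a small group again, though a methoxy rather than a methyl. Among the compounds with values here, the only measured step that bears on this change is a 13-fold higher number from compound 1 to compound 2 (1.12 log units; beyond the scatter), which ran in the opposite direction, from a small group to the phenyl. Removing the phenyl is therefore expected to bring the number back down, and the expected step is a 9.8-fold lower number from compound 2 to compound 3 (0.99 log units; beyond the scatter), with some allowance for the methoxy not being identical to the methyl. Compound 3 is estimated to give 1000 nM in this assay, within a range from 300 nM to 3500 nM.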

Compound 3, inhibition constant: > 100000 nM
Compound 3: a limit, no number; the forecaster's own chance of this, stated with the estimate: 5%; middle value at least 100-fold (2.00 log units) from the limit.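

Compound 3 gives a limit of the assay and not a number: the limit of > 100000 nM in this assay, at which 1 of the 3 values shown sits.

Even so, this assay shows the methoxy on this aromatic carbon on the weak side of both other groups, with an at least 10-fold higher number from compound 2 to compound 3 (1.00 log units; beyond the scatter) and with an at least 130-fold higher number from compound 1 to compound 3 (2.12 log units; beyond the scatter) as well. The earlier 13-fold higher number from compound 1 to compound 2 (1.12 log units; beyond the scatter) could be read as a simple rule that a small group is better than a large one on this carbon, but the methoxy goes against that reading, with 2 heavy atoms where the phenyl has 6. Heavy-atom count alone therefore does not set the order among compound 1, compound 2 and compound 3, and two small groups on the same carbon can lie far apart.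

As far as these compounds go, what stays open is whether the loss goes with the oxygen of the methoxy or with something else about the group, and a hydroxyl, an ethyl or a chlorine on the same carbon would help to separate these. From the compounds shown here alone, as compound 3 is a limit, the full size of both new steps also remains unknown.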